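This account rests on a few compounds, and the source may have more. Where it says the series, first, only, none or still open, it means among the compounds named here.

Two compounds share one core and differ in the ring attached to it and in the halogen on the phenoxy group. Compound 1 `O=C1N(CCCCCCOc2ccc(Cl)cc2)CCN1c1ccncc1` was tested in a functional assay on cells (Homo sapiens) for cytotoxicity; on this read-out higher numbers stand for lower toxicity in this test and lower numbers for higher toxicity in this test. In this assay compound 1 gave only a limit, > 25000 nM. Compound 2 `O=C1N(CCCCCCOc2ccc(Br)cc2)CCN1c1ccccc1` was tested the same way. In this assay compound 2 also gave only a limit, > 25000 nM. Compound 2 therefore stands at the edge of what the test can report, together with compound 1, since both values sit at the limit of > 25000 nM in this assay, at which 2 of the 2 values shown sit. Compound 3 `O=C1N(CCCCCCOc2ccc(Cl)cc2)CCN1c1ccccc1` has not yet been measured. It differs from compound 2 by chloro in place of bromo on an aromatic carbon, giving 4-chlorophenoxy, the same group that compound 1 carries. Among the compounds with values here, no step between two measured compounds is available, so the size of this change cannot be read from the data. The step from compound 2 to compound 3 is expected to be a step that the limit leaves unreadable from compound 2 to compound 3, no change beyond the scatter. For compound 3 the estimate in this assay is 40000 nM, with a range from 20000 nM to 100000 nM, and most likely again only a limit.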

Compound 3, half-maximal cytotoxic concentration: > 25000 nM
Compound 3 gave a limit, no number; the forecaster's own chance of this, stated with the estimate: 85%; the middle value lies beyond the limit too.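

Neither the comparison of compound 2 with compound 3 nor that of compound 1 with compound 3 gives a readable step, because all three results are limits and not numbers: the limit of > 25000 nM in this assay, at which 3 of the 3 values shown sit. The compounds shown leave open whether changing the halogen or the ring alters the result in this assay at all, and where each compound's true value lies.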